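The source may hold more compounds than are shown below. What is called first, only, known or untested is meant among the compounds shown, and "the series" means these compounds.

Measured compounds:
compound 1, `COc1ccc(C2SC(C)C(=O)Nc3c2c(C)nn3-c2ccccc2C)c(OC)c1` — 10500 nM
compound 2, `COC(=O)c1cccc(-c2ccc([C@H]3S[C@@H](C)C(=O)Nc4c3c(C)nn4-c3ccccc3C)cc2)c1` — "not active" (no number reported)
compound 3, `Cc1nn(-c2ccccc2Br)c2c1C(c1ccc(Oc3ccccc3)cc1)SC(C)C(=O)N2` — 1800 nM

The study follows a series built on one shared core, in which the aryl group on the saturated ring varies. In an assay on isolated protein for agonist activity at Bile acid receptor (Homo sapiens), read by AlphaScreen, with a stated time of 30 min (on this read-out higher numbers stand for an effect only at larger amounts of compound and lower numbers for an effect already at smaller amounts), compound 1 gives 10500 nM and compound 3 gives 1800 nM. In this assay compound 2 is recorded as "not active" (no number reported), and no concentration was reported for it, so it stands at the weak end of the set without a number of its own.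

Compound 4, `Cc1ccccc1-n1nc(C)c2c1NC(=O)[C@H](C)S[C@@H]2c1ccc(-c2ccccc2)cc1`, is not yet measured. It differs from compound 2 in one place: hydrogen in place of methoxycarbonyl on an aromatic carbon. Going by the values given here, since compound 2 has no number, no step from it can be sized, and no pair of measured compounds that differs in one place is available to set expectations. Compound 2 is reported as not active, so the change to compound 4 starts from a compound without a value; whether it becomes measurable is open. Compound 4 is estimated to give 6000 nM, between 1500 nM and 30000 nM, with a real chance that this assay again reports only a limit.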

Compound 4, half-maximal effective concentration: 990 nM
Compound 4: the middle estimate sits 6.1-fold (0.78 log units) above what was measured; the whole stated range lies above it.
By their numbers in this assay, from the lowest: compounds 4 and 3 (each within the scatter of the next); then compound 1.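

Compound 2 has no number, so the change from it to compound 4, which gives 990 nM, cannot be read as a step. The compounds shown leave open how large the effect of going from 3-(methoxycarbonyl)phenyl to phenyl is. No measurement here offers an explanation for the result.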